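Methoxyphenyl in Place of Chlorobenzyl on a Shared Core

This account rests on a few compounds, and the source may have more. Where it says the series, first, only, none or still open, it means among the compounds named here.

Compound 1, `C=C(Br)C(=O)Nc1cccc(-c2cn3nc(-c4ccccc4)sc3n2)c1`: 960 nM
Compound 2, `C=C(Br)C(=O)Nc1cccc(-c2cn3nc(Cc4ccc(Cl)cc4)sc3n2)c1`: 3300 nM
Compound 3, `Nc1cccc(-c2cn3nc(Cc4ccc(Cl)cc4)sc3n2)c1`: 42000 nM

In a functional assay on CCRF-CEM cells (Homo sapiens) for inhibition, read by cell counting, with a stated time of 3 days (a lower number here means a stronger inhibitor, a higher number a weaker inhibitor), compound 2 holds the second highest of the three numbers: compound 1 lies below it, a 3.4-fold higher number from compound 1 to compound 2 (0.54 log units; beyond the scatter), and compound 3 lies above it, a 13-fold higher number from compound 2 to compound 3 (1.10 log units; beyond the scatter). Compound 4, `C=C(Br)C(=O)Nc1cccc(-c2cn3nc(-c4ccc(OC)cc4)sc3n2)c1`, differs from compound 2 in one place: 4-methoxyphenyl in place of 4-chlorobenzyl on an aromatic carbon. The step that bears on this exchange is the one in which a phenyl on that same aromatic carbon gave way to the 4-chlorobenzyl, a 3.4-fold higher number from compound 1 to compound 2 (0.54 log units; beyond the scatter). Compound 4 reverses that exchange, though with a methoxy group added to the ring, for which no measured comparison exists. A lower number of about that size is therefore expected, a 2.8-fold lower number from compound 2 to compound 4 (0.44 log units; beyond the scatter). Compound 4 is estimated at 1200 nM, within 400 nM to 4000 nM.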

Compound 4, half-maximal inhibitory concentration: 1200 nM
Beside the measured number, compound 4's estimate shows no gap at the digits printed, within the range that was stated.
By their numbers in this assay, from the lowest: compounds 1 and 4 (each within the scatter of the next); then compound 2; then compound 3.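

Compound 4 shows that 4-methoxyphenyl at this aromatic carbon gives a lower number than 4-chlorobenzyl (a 2.8-fold lower number from compound 2 to compound 4 (0.44 log units; beyond the scatter)). Methoxy in place of hydrogen on the phenyl ring cannot be told apart from the scatter (a 1.3-fold higher number from compound 1 to compound 4 (0.10 log units; within the scatter)), so this position accepts that group without a measurable penalty. Nothing measured here explains either result.

Still open, from the compounds shown here alone, is how an amine or a carboxylic acid would fare in place of the methoxy. A plain benzyl group would also be needed to separate the chlorine's contribution from that of the extra carbon.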